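The source may report more compounds than this note shows. Statements on the series, on what has been measured and on what is new or still open speak of the compounds shown alone.

Measured in an ADME assay on microsomes from liver (Homo sapiens) for metabolic stability, read by LC-MS, with a stated time of 30 min, tested at 1 uM; on this read-out higher numbers stand for a more stable compound and lower numbers for a less stable compound:
Compound 1 `O=C(NCc1ccc(S(=O)(=O)c2ccccc2)cc1)c1nc2cnccc2[nH]1`: 73%
Compound 2 `O=C(NCc1ccc(S(=O)(=O)c2cccc(F)c2)cc1)c1cc2cnccc2[nH]1`: 79%

In this assay, compound 1 gives 73% and compound 2 gives 79%, two values within the usual scatter of each other. Compound 3 `O=C(NCc1ccc(S(=O)(=O)c2ccccc2)cc1)c1ccc2nccn2c1` has not yet been measured. It differs from compound 1 in a single place, on a carbonyl carbon whose other neighbour is an amide-type nitrogen: a group of 9 heavy atoms (7 carbon, 2 nitrogen; one five-membered aromatic ring with 2 hetero atoms, one six-membered aromatic ring with 1 hetero atom) in place of a group of 9 heavy atoms (6 carbon, 3 nitrogen; one five-membered aromatic ring with 2 hetero atoms, one six-membered aromatic ring with 1 hetero atom), on a carbonyl carbon. Within the data shown here, no measured step between compounds that differ in one place is available, so any expectation rests on compound 1 at 73% and on this structural change alone. A modest fall is expected, and it may not exceed the scatter. The expected step is a number 7 percentage points lower from compound 1 to compound 3 (within the scatter). For compound 3 the estimated value is 66%, with an expected range from 44% to 86%.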

Compound 3, percent of the compound remaining: 77%
Beside the measured number, compound 3's estimate is 11 percentage points below it, within the range that was stated.
By their numbers in this assay, from the lowest: compounds 1, 3 and 2 (each within the scatter of the next).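

In this assay, the exchange on the carbonyl carbon whose other neighbour is the amide-type nitrogen gives a number 4 percentage points higher from compound 1 to compound 3 (within the scatter). At this position, therefore, a group with 1 hydrogen-bond donor gave way to a group of the same heavy-atom count with 0 hydrogen-bond donors, and the read-out showed no change beyond the scatter. No supporting measurement is available to explain this result.

The compounds shown leave open whether a group carrying an amine or a carboxylic acid on this carbonyl carbon would also stay within the scatter of compound 1. This single step also cannot show whether the same exchange would behave alike on a core bearing a different substituent elsewhere.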